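The compounds below may be only part of what the source reports. "The series", "measured", "known", "first", "only" and "open" are said of these compounds alone.

The measured compounds:

Compound 1 `O=c1c(-c2ccc(O)cc2)coc2cc(OCCOCCOCCO)ccc12` in an assay (Cricetulus griseus) for inhibition of aldehyde dehydrogenase, mitochondrial (Homo sapiens) (a lower number here means a stronger inhibitor, a higher number a weaker inhibitor), gives 40 nM.
Compound 2 `CCCCCCOc1ccc2c(=O)c(-c3ccc(O)cc3)coc2c1` in this assay gives 1500 nM.
Compound 3 `O=C(O)CCCCOc1ccc2c(=O)c(-c3ccc(O)cc3)coc2c1` in this assay gives 100 nM.

Compound 3 stands second highest of the three numbers: closest to compound 1, which is a 15-fold lower number from compound 2 to compound 3 (1.18 log units; beyond the scatter) away in the other sense, while the far end is compound 2, reached by reversing the step of a 15-fold lower number from compound 2 to compound 3 (1.18 log units; beyond the scatter). The unmeasured compound 4 `CCOC(=O)CCCCCOc1ccc2c(=O)c(-c3ccc(O)cc3)coc2c1` differs from compound 3 by (ethoxycarbonyl)methyl in place of carboxy on a saturated chain carbon, four bonds along the chain from an oxygen on an aromatic ring.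

Going by the values given here, two measured steps bear on this. The step of a 15-fold lower number from compound 2 to compound 3 (1.18 log units; beyond the scatter) shows that putting a carboxy on the chain where compound 2 carries only carbons lowers the number a great deal. The step of a 38-fold higher number from compound 1 to compound 2 (1.57 log units; beyond the scatter) shows the same from the other side: removing the oxygen-bearing chain of compound 1 in favour of a plain carbon chain raises it strongly. Compound 4 keeps a carbonyl and its acceptors but loses the carboxy donor and gains chain carbons, so it sits between compound 3 and compound 2. A step upward beyond the scatter is expected, a 4.5-fold higher number from compound 3 to compound 4 (0.65 log units; beyond the scatter), and compound 4 is estimated at 450 nM with a range from 150 nM to 1500 nM.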

Compound 4, half-maximal inhibitory concentration: 280 nM
Beside the measured number, compound 4's estimate is 1.6-fold (0.21 log units) above it; the range from low to high includes it.
By their numbers in this assay, from the lowest: compound 1; then compound 3; then compound 4; then compound 2.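

Replacing carboxy with (ethoxycarbonyl)methyl at this place on the chain gives a 2.8-fold higher number from compound 3 to compound 4 (0.45 log units; beyond the scatter) in this assay, so a group with no hydrogen-bond donor can stand here at a modest cost. The same end group still keeps a clear advantage over the plain chain, with a 5.4-fold lower number from compound 2 to compound 4 (0.73 log units; beyond the scatter), although it does not match the chain of compound 1, as a 7.0-fold higher number from compound 1 to compound 4 (0.85 log units; beyond the scatter) shows. No measurement here explains why these numbers move as they do.

This change both masks the carboxy and adds chain carbons. The data do not separate these two parts of the step. A carboxylic acid on the longer chain of compound 4, or an amine in place of the carboxy, would help to separate the length of the chain from the nature of its end group.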